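Trifluoromethyl position change from compound 2 to compound 3

The compounds below may be only part of what the source reports. "The series", "measured", "known", "first", "only" and "open" are said of these compounds alone.

Measured so far:
- in a functional assay on MIA PaCa-2 cells (Homo sapiens) for inhibition, read by MTT assay, with a stated time of 72 h (a lower number here means a stronger inhibitor, a higher number a weaker inhibitor), compound 1 `COc1cc(NC(C)CCCNC(=O)Nc2cccc(Cl)c2)c2ncccc2c1` gives 21000 nM as its value
- in this assay compound 2 `COc1cc(NC(C)CCCNC(=O)NNC(=O)Nc2ccc(C(F)(F)F)cc2)c2ncccc2c1` gives 19000 nM as its value

Compound 2 stands within the scatter of compound 1, so these two values do not separate. Compound 3 `COc1cc(NC(C)CCCNC(=O)NNC(=O)Nc2cccc(C(F)(F)F)c2)c2ncccc2c1` has 3-(trifluoromethyl)phenyl in place of the 4-(trifluoromethyl)phenyl of compound 2 on an amide-type nitrogen (3-(trifluoromethyl)phenyl in place of 4-(trifluoromethyl)phenyl on an amide-type nitrogen). Among the measured compounds shown here, no measured pair tests this kind of change. In this assay no step beyond the scatter is expected. The expected 1.1-fold lower number from compound 2 to compound 3 (0.02 log units; within the scatter) is therefore small. Compound 3 is estimated at 18000 nM with an expected range of 8000 nM to 40000 nM for the measurement.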

Compound 3, half-maximal inhibitory concentration: 5600 nM
Beside the measured number, compound 3's estimate is 3.2-fold (0.51 log units) above it; measured number outside the range, below it.
By their numbers in this assay, from the lowest: compound 3; then compounds 2 and 1 (each within the scatter of the next).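

In this assay, replacing 4-(trifluoromethyl)phenyl with 3-(trifluoromethyl)phenyl on the amide-type nitrogen gives a 3.4-fold lower number from compound 2 to compound 3 (0.53 log units; beyond the scatter) and separates two compounds in the series by more than the scatter. Since the two compounds have the same atoms joined differently, the read-out responds to the placement of the trifluoromethyl group alone, which compound 1 and compound 2 could not show. No available evidence accounts for this step.

From the compounds shown here alone, whether a nitrile or a carboxylic acid in place of trifluoromethyl on this phenyl would follow the same trend remains open. So does the effect of a longer chain on the shared core.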